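This account rests on a few compounds, and the source may have more. Where it says the series, first, only, none or still open, it means among the compounds named here.

Measured so far:
- Compound 1 `CN(C(=O)NC(=O)c1c(F)cccc1F)c1nc(C(F)(F)F)c(C(=O)N/N=C/c2cccc(C(F)(F)F)c2)s1`: 27.9 ug/mL
- Compound 2 `CN(C(=O)NC(=O)c1ccc(C(F)(F)F)cc1)c1nc(C(F)(F)F)c(C(=O)N/N=C/c2cccc(C(F)(F)F)c2)s1`: 7.95 ug/mL

In a functional assay on HepG2 cells (Homo sapiens) for inhibition, read by MTT assay, with a stated time of 72 h (a higher number here means a weaker inhibitor, a lower number a stronger inhibitor), compound 2 holds the lower of the two numbers; the move a 3.5-fold lower number from compound 1 to compound 2 (0.55 log units; beyond the scatter) separates it from compound 1. Compound 3 `CN(C(=O)NC(=O)c1ccccc1F)c1nc(C(F)(F)F)c(C(=O)N/N=C/c2cccc(C(F)(F)F)c2)s1` differs from compound 2 in one place: 2-fluorophenyl in place of 4-(trifluoromethyl)phenyl on a carbonyl carbon. Going by the values given here, the only step that bears on this spot is the one from compound 1 to compound 2, where a fluorinated phenyl gave way to a trifluoromethyl-bearing one and the number fell modestly. Going back to a fluorinated phenyl is therefore expected to move the number up by a 2.3-fold higher number from compound 2 to compound 3 (0.35 log units; beyond the scatter). Compound 3 is estimated at 18 ug/mL, between 8 ug/mL and 40 ug/mL.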

Compound 3, half-maximal inhibitory concentration: 20.3 ug/mL
Compound 3: middle estimate off by 1.1-fold (0.05 log units), on the low side; measured number inside the range.
By their numbers in this assay, from the lowest: compound 2; then compounds 3 and 1 (each within the scatter of the next).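

In this assay, the 4-(trifluoromethyl)phenyl group on this carbonyl carbon now stands apart from a second fluorinated partner, with a 2.6-fold higher number from compound 2 to compound 3 (0.41 log units; beyond the scatter) adding to the earlier step from compound 1. The count of fluoro groups on the ring shows no readable effect, since the change to hydrogen gives a 1.4-fold lower number from compound 1 to compound 3 (0.14 log units; within the scatter). No measurement at hand explains either step.

From the compounds shown here alone, whether compound 2 owes its lower number to the trifluoromethyl group itself or to where that group sits remains open. A plain phenyl, a methoxyphenyl or an aminophenyl on this carbonyl carbon would help separate the two.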